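Carbocyclic nucleoside analogs: hydroxy to amino on the core

The source may report more compounds than this note shows. Statements on the series, on what has been measured and on what is new or still open speak of the compounds shown alone.

Measured so far:
compound 1 `Nc1nc(O)c2nnn(C3CC(CO)C(O)C3O)c2n1` — > 100 ug/mL in a functional assay on cells (Cancer cell lines, Homo sapiens) for cytotoxicity (a lower number here means that less compound is needed, a higher number that more compound is needed for the effect), a limit of the assay, not a number.
compound 2 `CNc1nc(N)nc2c1ncn2C1CC(CO)C(O)C1O` — 18 ug/mL in this assay.

Compound 1 stands only at the limit of > 100 ug/mL in this assay, at which 1 of the 2 values shown sits. No number for it exists within the measured range of this assay, so its place among the values shown is simply the limit itself. Compound 2, with its own core, gives a real value in this assay and serves as the only numeric anchor in the set.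

Compound 3 `Nc1nc(N)c2nnn(C3CC(CO)C(O)C3O)c2n1` differs from compound 1 by amino in place of hydroxy on an aromatic carbon. For the measured compounds named here, no step between two measured compounds covers this change, so its size has to be expected rather than read.

The expected step in this assay is an at least 2.0-fold lower number from compound 1 to compound 3 (0.30 log units; that floor lies within the scatter), toward less compound needed, beyond the usual scatter. The expectation leans on compound 2, which in this assay gives 18 ug/mL with two amino groups on its core. Compound 3 is estimated at 50 ug/mL, with a range from 12 ug/mL to 100 ug/mL, and a fair chance that only a limit is returned.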

Compound 3, concentration for half-maximal effect: > 100 ug/mL
Compound 3 ended at the assay's limit; the forecaster's own chance of this, stated with the estimate: 45%; middle value at least 2.0-fold (0.30 log units) from the limit.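

Compound 1 and compound 3 both sit at a limit of the assay and not at a number, so the change from hydroxy to amino gives no readable step between them: the limit of > 100 ug/mL in this assay, at which 2 of the 3 values shown sit.

The compounds shown leave open whether amino in place of hydroxy on an aromatic carbon of the shared core changes the result in this assay at all.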